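Swapping Cyclopropylamino for a Hydroxycarbamoyl-Bearing Chain

This account rests on a few compounds, and the source may have more. Where it says the series, first, only, none or still open, it means among the compounds named here.

Compound 3, `COc1ccc2c(c1)NC(=O)CN2c1nc(NC2CC2)nc2ccccc12`, gives 2.11 nM in a functional assay on KB cells (Homo sapiens) for inhibition, read by sulforhodamine B assay, with a stated time of 48 h; a higher number here means a weaker inhibitor of growth, a lower number a stronger inhibitor of growth.
Compound 2, `COc1ccc2c(c1)NC(=O)CN2c1nc(Nc2ccc(C#N)cc2)nc2ccccc12`, gives 5.39 nM in this assay.
Compound 1, `COc1ccc2c(c1)NC(=O)CN2c1nc(Nc2cccc(C#N)c2)nc2ccccc12`, gives 61.5 nM in this assay.

Compound 3 has the lowest number of the three: there is a 2.6-fold lower number from compound 2 to compound 3 (0.41 log units; beyond the scatter) and a 29-fold lower number from compound 1 to compound 3 (1.46 log units; beyond the scatter). Compound 4, `COc1ccc2c(c1)NC(=O)CN2c1nc(COCCCC(=O)NO)nc2ccccc12`, differs from compound 3 by (3-(hydroxycarbamoyl)propoxy)methyl in place of cyclopropylamino on an aromatic carbon. The measured steps, an 11-fold lower number from compound 1 to compound 2 (1.06 log units; beyond the scatter), a 29-fold lower number from compound 1 to compound 3 (1.46 log units; beyond the scatter) and a 2.6-fold lower number from compound 2 to compound 3 (0.41 log units; beyond the scatter), all keep an amine on that carbon and vary only the group on it; none replaces the amine with a chain, so none bears directly on this change. They do show that this position moves the number strongly, and compound 3 already sits lowest. Compound 4 is therefore expected at 30 nM, within 4 nM to 300 nM, which means a 14-fold higher number from compound 3 to compound 4 (1.15 log units; beyond the scatter) is expected.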

Compound 4, concentration for 50% growth inhibition: 307 nM
Estimate against measurement, compound 4: 10-fold (1.01 log units) below; the measured number lies above the stated range.
By their numbers in this assay, from the lowest: compound 3; then compound 2; then compound 1; then compound 4.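

In this assay, compound 4 is the weakest inhibitor of growth of the four, so at this carbon the (3-(hydroxycarbamoyl)propoxy)methyl chain does worse than all three amines: there is a 150-fold higher number from compound 3 to compound 4 (2.16 log units; beyond the scatter), a 57-fold higher number from compound 2 to compound 4 (1.76 log units; beyond the scatter) and a 5.0-fold higher number from compound 1 to compound 4 (0.70 log units; beyond the scatter). No evidence is given that explains this loss.

As far as these compounds go, it remains open whether the loss follows from removing the amine or from the chain itself. A similar chain joined through an amine, or one ending in a carboxylic acid, would help separate the two.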